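Compound 4: acetyl in place of dimethylamino

This account rests on a few compounds, and the source may have more. Where it says the series, first, only, none or still open, it means among the compounds named here.

In a functional assay on DU-145 cells (Homo sapiens) for inhibition, read by trypan blue exclusion, with a stated time of 96 h (a lower number here means a stronger inhibitor of growth, a higher number a weaker inhibitor of growth), compound 1 `Cc1ccc(S/C(=C/c2c[nH]c3ccccc23)C(=O)c2ccc(Br)cc2)cc1` gives 10000 nM, and compound 2 `Cc1ccc(S/C(=C/c2ccc(-c3ccccc3)cc2)C(=O)c2ccc(Br)cc2)cc1` gives 50000 nM. Compound 3 `Cc1ccc(S/C(=C/c2ccc(N(C)C)cc2)C(=O)c2ccc(Br)cc2)cc1` gives > 100000 nM, which is a limit of the assay and not a number. Compound 4 `CC(=O)c1ccc(/C=C(/Sc2ccc(C)cc2)C(=O)c2ccc(Br)cc2)cc1` carries acetyl in place of dimethylamino on an aromatic carbon, para to a large group (acetyl in place of dimethylamino on an aromatic carbon). For the measured compounds named here, two measured steps bear on this change: an at least 10-fold higher number from compound 1 to compound 3 (1.00 log units; beyond the scatter) lies beyond the scatter, while an at least 2.0-fold higher number from compound 2 to compound 3 (0.30 log units; that floor lies within the scatter) has a floor within it. Neither step involves acetyl, so the guide is loose. In this assay the expected step is modest and towards a lower number, an at least 2.2-fold lower number from compound 3 to compound 4 (0.34 log units; beyond the scatter). Compound 4 is estimated at 45000 nM, within a range of 15000 nM to 100000 nM.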

Compound 4, concentration for 50% growth inhibition: 50000 nM
Compound 4: middle estimate off by 1.1-fold (0.05 log units), on the low side, and the stated range covers the measured number.
By their numbers in this assay, from the lowest: compound 1; then compounds 2 and 4 (each within the scatter of the next). At a limit, above all of these: compound 3.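

Acetyl and phenyl on this aromatic carbon, para to a large group, read alike in this assay (no change at the digits printed from compound 2 to compound 4 (within the scatter)). The 4-acetylphenyl of compound 4 still does not match the 1H-indol-3-yl of compound 1 (a 5.0-fold higher number from compound 1 to compound 4 (0.70 log units; beyond the scatter)). Acetyl gives a measured number where dimethylamino leaves compound 3 at a limit of the assay, so this step (an at least 2.0-fold lower number from compound 3 to compound 4 (0.30 log units; that floor lies within the scatter)) is only a floor: the limit of > 100000 nM in this assay, at which 1 of the 4 values shown sits.

Open, from the compounds shown here alone, is whether a carboxylic acid, a primary amide or a methoxy group at this place would separate from compound 4 beyond the scatter.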